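Swapping hydroxy for 1-hydroxy-1-methylethyl

The source may hold more compounds than are shown below. What is called first, only, known or untested is meant among the compounds shown, and "the series" means these compounds.

- Compound 1 `CC(=O)NCc1cccc(Cn2nc(NS(=O)(=O)c3ccc(Cl)s3)c3c(F)cccc32)c1` (3)
- Compound 2 `CC(=O)NCc1cccc(Cn2nc(NS(=O)(=O)c3ccc(Cl)s3)c3c(O)cccc32)c1` (2.9)

Going by the values given here, in a physicochemical assay for lipophilicity (a lower number here means a more polar compound, a higher number a more lipophilic compound), compound 2 stands within the scatter of compound 1, the only other measured compound. Compound 3 `CC(=O)NCc1cccc(Cn2nc(NS(=O)(=O)c3ccc(Cl)s3)c3c(C(C)(C)O)cccc32)c1` differs from compound 2 by 1-hydroxy-1-methylethyl in place of hydroxy on an aromatic carbon in a single change, 1-hydroxy-1-methylethyl in place of hydroxy on an aromatic carbon. Among the compounds with values here, the only measured step (a number 0.10 log units lower from compound 1 to compound 2 (within the scatter)) exchanged other groups at that carbon and is a weak guide. A small rise is expected, and the estimated step (a number 0.30 log units higher from compound 2 to compound 3 (within the scatter)) may stay within the scatter. In this assay compound 3 is expected at 3.2 within an estimated range (2.8 to 3.6).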

Compound 3, distribution coefficient: 2.9
Compound 3: the middle estimate sits 0.30 log units above what was measured; the range from low to high includes it.
By their numbers in this assay, from the lowest: compounds 2, 3 and 1 (each within the scatter of the next).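

In this assay, putting the larger 1-hydroxy-1-methylethyl group on this aromatic carbon in place of hydroxy gives no change at the digits printed from compound 2 to compound 3 (within the scatter) and in place of fluoro gives a number 0.10 log units lower from compound 1 to compound 3 (within the scatter) at the same carbon. All three groups at this carbon therefore sit within the scatter of one another, which the fluoro and hydroxy pair alone could not show for a group with more heavy atoms. Nothing shown here gives a reason for this result. As far as these compounds go, whether an amine or a carboxylic acid at this carbon would give a number beyond the scatter stays open, as does the outcome for a longer chain.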